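The source may hold more compounds than are shown below. What is called first, only, known or untested is meant among the compounds shown, and "the series" means these compounds.

In a functional assay on CHO/Galpha16 cells for antagonist activity at prostaglandin E2 receptor EP4 subtype (Homo sapiens), read by calcium flux, with a stated time of 15 min (a lower number here means a stronger inhibitor, a higher number a weaker inhibitor), compound 2 `C[C@H](NC(=O)c1c(Cc2ccc(F)cc2)sc2c1CCOC2)c1ccc(C(=O)NN)cc1` gives 74.9 nM. That is the second highest of three numbers: compound 1 `CON(C)C(=O)c1ccc([C@H](C)NC(=O)c2c(Cc3ccc(F)cc3)sc3c2CCOC3)cc1` gives 187 nM, while compound 3 `C[C@H](NC(=O)c1c(Cc2cccc(F)c2)sc2c1CCOC2)c1ccc(C(=O)O)cc1` gives 5.1 nM, the lowest of the three. Compound 4 `COC(=O)c1ccc([C@H](C)NC(=O)c2c(Cc3ccc(F)cc3)sc3c2CCOC3)cc1` has not yet been measured; it differs from compound 2 by methoxy in place of aminoamino on a carbonyl carbon. For the measured compounds named here, one measured step touches the same place: a 2.5-fold lower number from compound 1 to compound 2 (0.40 log units; beyond the scatter). That step shows that exchanging the group on this carbonyl carbon shifts the number only modestly, so putting methoxy there in compound 4 is expected to move the number back up by a similar amount, a 2.7-fold higher number from compound 2 to compound 4 (0.43 log units; beyond the scatter). Compound 4 is therefore estimated at 200 nM, within a range of 60 nM to 700 nM.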

Compound 4, half-maximal inhibitory concentration: > 1000 nM
Compound 4: a limit, no number (the forecaster's own chance of this, stated with the estimate: 5%); middle value at least 5.0-fold (0.69 log units) away from the limit.
By their numbers in this assay, from the lowest: compound 3; then compound 2; then compound 1. At a limit, above all of these: compound 4.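

Compound 4 gives > 1000 nM, which is a limit of the assay and not a number. Its methoxy group shows that this carbonyl carbon is more sensitive than the earlier modest step suggested, with an at least 13-fold higher number from compound 2 to compound 4 (1.12 log units; beyond the scatter) and an at least 5.3-fold higher number from compound 1 to compound 4 (0.72 log units; beyond the scatter). Aminoamino and methoxy(methyl)amino both leave a measurable number here, whereas methoxy does not.

As far as these compounds go, how far compound 4 lies past its limit remains unknown. Also open, from the compounds shown here alone, is how an amino or ethoxy group on this carbonyl carbon would read with the rest of compound 2 unchanged.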